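A Second Methyl on a Compound at the Limit

The source may report more compounds than this note shows. Statements on the series, on what has been measured and on what is new or still open speak of the compounds shown alone.

In an ADME assay on HCT-116 cells (Homo sapiens) for cytotoxicity, read by CellTiter-Glo, with a stated time of 72 h (a higher number here means a weaker inhibitor, a lower number a stronger inhibitor), compound 1 (`Cc1cc(C)c(S(=O)(=O)N2CCC(N3CCC(C)CC3)CC2)c(C)c1`) gives > 5000 nM as its reading, which is a limit and not a number. Compound 2 (`Cc1cc(C)c(S(=O)(=O)N2CCC(N3CCC(c4ccccc4)CC3)CC2)c(C)c1`) gives > 5000 nM as its reading, again a limit. The two compounds share the limit of > 5000 nM in this assay, at which 2 of the 2 values shown sit, in the data, so no measured size is available to build on. Compound 3 (`Cc1cc(C)c(S(=O)(=O)N2CCC(N3CC(C)CC(C)C3)CC2)c(C)c1`) differs from compound 1 in one group: 3,5-dimethylpiperidin-1-yl in place of 4-methylpiperidin-1-yl on a saturated ring carbon on the shared core. Among the compounds with values here, the only measured step that bears on this is a step that the two limits leave unreadable from compound 1 to compound 2 with phenyl in place of methyl on a saturated ring carbon, and it left the reading at the limit. No change beyond the scatter is therefore expected in this assay for this swap. The expected change is a step that the limit leaves unreadable from compound 1 to compound 3 in size. Compound 3 is estimated at 6000 nM within a range from 3000 nM to 12000 nM and will probably be reported as a limit too.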

Compound 3, half-maximal inhibitory concentration: > 5000 nM
Compound 3 was reported as a limit (the forecaster's own chance of this, stated with the estimate: 85%); the middle value does not contradict the limit.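

The step from compound 1 to compound 3 cannot be read, because both readings are limits and not numbers: the limit of > 5000 nM in this assay, at which 3 of the 3 values shown sit. The compounds shown leave open what concentration any of the three would need for a half-maximal effect in this assay, and whether either swap changes it.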